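N-methylation of the cyclic peptide compound 2

The source may report more compounds than this note shows. Statements on the series, on what has been measured and on what is new or still open speak of the compounds shown alone.

Values in a functional assay (plasma) for inhibition, with Canis familiaris (Canis lupus familiaris) as the target; a lower number here means a stronger inhibitor, a higher number a weaker inhibitor:
- compound 1 `CC(=O)N[C@H]1CSSC(C)(C)[C@H](C(N)=O)NC(=O)[C@H](CC(=O)O)NC(=O)CNC(=O)[C@H](CCCN=C(N)N)N(C)C1=O`: 360 nM
- compound 2 `CC(=O)N[C@@H]1CSSC(C)(C)[C@H](C(N)=O)NC(=O)[C@@H](CC(=O)O)NC(=O)CNC(=O)[C@H](CCCN=C(N)N)NC1=O`: 4120 nM
- compound 3 `CC(=O)N[C@H]1CSSC(C)(C)[C@H](C(N)=O)NC(=O)[C@@H](CC(=O)O)NC(=O)CNC(=O)[C@@H](CCCN=C(N)N)NC1=O`: 98700 nM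

In this assay compound 2 gives 4120 nM, the second highest of the three numbers. Compound 1 lies below it and compound 3 above it, both beyond the scatter.

Compound 4 `CC(=O)N[C@@H]1CSSC(C)(C)[C@H](C(N)=O)NC(=O)[C@@H](CC(=O)O)NC(=O)CNC(=O)[C@H](CCCN=C(N)N)N(C)C1=O` keeps the configuration of compound 2 and has methyl in place of hydrogen on an amide-type nitrogen in a ring.

Within the data shown here, no measured step isolates this methyl. Among the measured compounds shown here, the only step available, a 24-fold higher number from compound 2 to compound 3 (1.38 log units; beyond the scatter), is large, and it can be traced only to the fact that compounds 2 and 3 differ only in the configuration as drawn. It bears on the question indirectly, as a warning that values cannot be carried freely between compounds drawn with different configurations. That matters here, since compound 1 carries the same methyl but differs from compound 4 in configuration at ring carbons.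

A lower number is still expected because compound 1 gives 360 nM with the methyl in place while compound 2 gives 4120 nM without it. The expected change is a 5.9-fold lower number from compound 2 to compound 4 (0.77 log units; beyond the scatter). For compound 4 the estimate is 700 nM, with an expected range from 150 nM to 4000 nM.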

Compound 4, half-maximal inhibitory concentration: 1790 nM
Compound 4: middle estimate off by 2.6-fold (0.41 log units), on the low side; measured number inside the range.
By their numbers in this assay, from the lowest: compound 1; then compound 4; then compound 2; then compound 3.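

In this assay, methyl in place of hydrogen on an amide-type nitrogen in a ring now has a reading of its own, free of any change in configuration: a 2.3-fold lower number from compound 2 to compound 4 (0.36 log units; beyond the scatter). At this nitrogen, then, in the configuration of compound 2, the methyl goes with a modest fall in the number rather than a rise. The methyl alone does not account for the low number of compound 1, since the next step has the methyl on both sides, and a 5.0-fold higher number from compound 1 to compound 4 (0.70 log units; beyond the scatter) can be traced to a single source: the fact that compounds 1 and 4 differ only in the configuration as drawn.

Still open, going by these compounds, is whether the methyl step has the same size or even the same direction in the configuration of compound 1 or compound 3, and whether methyl on the other amide-type nitrogens of the ring reads as it does here. Also open is how an ethyl group or a longer chain on this nitrogen would compare with methyl, and the compounds shown give no reason for either step.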